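A few compounds are considered here, and "the series" means these few. Any claim that something is new, unique, unknown or untested is made for them only; others in the source may bear on it.

Measured compounds:
Compound 1, `CC(=O)N[C@@H]1CCC[C@H](C(=O)Nc2cc(-c3cnn(C)c3C)c(Cl)cn2)C1`: in an ADME assay on cells (Hepatocyte, Homo sapiens) for metabolic stability, using equilibrium dialysis (on this read-out lower numbers stand for slow clearance and higher numbers for fast clearance), compound 1 gives < 1 uL/min.
Compound 2, `CC(=O)N[C@@H]1CCC[C@H](C(=O)Nc2cc(-c3cnn4c3CC(C)(C)C4)c(F)cn2)C1`: in this assay compound 2 gives 2.6 uL/min.

The value for compound 1 is a limit of the assay, not a number, as the limit of < 1 uL/min in this assay, at which 1 of the 2 values shown sits, records. Among the compounds with values here, compound 2 therefore holds the only actual number among the two values shown, and its position relative to compound 1 cannot be stated beyond what the limit allows.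

The step under consideration leads from compound 2 to compound 3, `CC(=O)N[C@@H]1CCC[C@H](C(=O)Nc2cc(-c3cnn4c3CC(C)(C)C4)c(C#N)cn2)C1`, which has not yet been measured in this assay. The change is cyano in place of fluoro on an aromatic carbon. Since no step between measured compounds is shown, there is nothing in the data to calibrate what this exchange does to clearance. The expectation is that compound 3 stays close to compound 2, with any step of a 1.3-fold lower number from compound 2 to compound 3 (0.11 log units; within the scatter) small and most likely within the usual scatter. Compound 3 is estimated at 2 uL/min, with a range from 0.8 uL/min to 5 uL/min, and there is a fair chance that this assay reports only a limit for it.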

Compound 3, intrinsic clearance in a liver preparation (reported as CLH), per the amount of preparation that the assay uses in the Hepatocyte assay: < 1 uL/min
Compound 3: a limit, no number; the forecaster's own chance of this, stated with the estimate: 25%; at least 2.0-fold (0.30 log units) between middle value and limit.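

Within the data shown here, in the Hepatocyte assay, cyano in place of fluoro on an aromatic carbon, ortho to a large group and two atoms from the ring nitrogen, gives an at least 2.6-fold lower number from compound 2 to compound 3 (0.41 log units; beyond the scatter), the first step that can be read at this position. In a physicochemical assay for lipophilicity, using the shake flask method, measured as octanol-water partition, at pH 7.4 (on this read-out lower numbers stand for lower lipophilicity and higher numbers for higher lipophilicity), compound 2 gives 3.3 and compound 3 gives 3.2, two values within the scatter of each other, so this pair separates on clearance but not on the distribution coefficient. The value of compound 3 in the Hepatocyte assay is a limit of the assay and not a number, so the printed step gives only the smallest size it can have, and the full size stays unknown: the limit of < 1 uL/min in the Hepatocyte assay, at which 2 of the 3 values shown sit.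

Compound 1 and compound 3 differ in more than one place and both stand at the limit, so the Hepatocyte assay does not order them. Going by these compounds, it remains open whether a methoxy or trifluoromethyl group on this aromatic carbon would also give a limit, and whether cyano in place of the chloro of compound 1 would do the same on that compound's core.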